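Cytotoxicity notes on a fused-core series with pyridyl arms

The source may hold more compounds than are shown below. What is called first, only, known or untested is meant among the compounds shown, and "the series" means these compounds.

The compounds share a fused two-ring core that carries an amino substituent and a pyridyl arm. In an ADME assay on THP-1 cells (Homo sapiens) for cytotoxicity (a lower number here means that less compound is tolerated, a higher number that more compound is tolerated), compound 1 `c1ccc(-c2nc3ccccn3c2NCC2CC2)nc1` gives 19400 nM. Compound 2 `COc1ccn2c(Nc3ccc(F)cn3)c(-c3ccccn3)nc2c1` gives 16000 nM in this assay, and the two numbers sit within the usual scatter of each other. Compound 3 `c1cncc(-c2nc3ccccn3c2NC2CCCC2)c1` returns no number in this assay, only the limit > 50000 nM. This is the limit of > 50000 nM in this assay, at which 1 of the 3 values shown sits. Compound 3 thus stands at the edge of what this assay reports, whereas compound 1 and compound 2 each give a measurable half-maximal cytotoxic concentration.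

Compound 4 `Cc1cc(-c2nc3ccccn3c2NC2CCCC2)ccn1` is the next member, not yet measured in this assay. Its change from compound 3 is 2-methylpyridin-4-yl in place of pyridin-3-yl on an aromatic carbon of the core. Among the compounds with values here, no measured pair shows a step of this kind, so the expectation rests on compound 3 alone. The step of a number no higher from compound 3 to compound 4 (the limit leaves the size open) is expected to be small, with no direction beyond the scatter. For compound 4 the estimated half-maximal cytotoxic concentration is 50000 nM, in a range from 20000 nM to 100000 nM, with a real chance that this assay again reports only a limit.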

Compound 4, half-maximal cytotoxic concentration: > 50000 nM
Compound 4: no number, only a limit; the forecaster's own chance of this, stated with the estimate: 55%; the middle value sits exactly at the limit.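

Compound 3 and compound 4 both return only a limit in this assay and so the step between them cannot be read. The compounds shown leave open whether 2-methylpyridin-4-yl in place of pyridin-3-yl on an aromatic carbon shifts the half-maximal cytotoxic concentration at all, and in which direction.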